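Methyl in Place of Methoxy on a Hydroxamic Acid Inhibitor

This account rests on a few compounds, and the source may have more. Where it says the series, first, only, none or still open, it means among the compounds named here.

Of the compounds shown here, two have been measured in an assay on Sf9 cells for inhibition of protein deacetylase HDAC6 (Homo sapiens), read by fluorescence, with stated times of 90 min and 30 min; on this read-out higher numbers stand for weaker inhibition and lower numbers for stronger inhibition. Compound 1, `Cc1ccc(NC(=O)CCN(Cc2ccc(C(=O)NO)cc2)C(=O)c2cc(C)cc(C)c2)cc1`, gives 31.1 nM in this assay. Compound 2, `COc1ccc(C(=O)N(CCC(=O)NCc2ccccc2)Cc2ccc(C(=O)NO)cc2)cc1`, gives 25.3 nM in this assay. Compound 2 stands on the lower of the two numbers, but its gap to compound 1 lies within the usual scatter, so the two cannot be set in order. For the measured compounds named here, no pair differing in a single place has been measured, so no step size is known from the data.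

Compound 3, `Cc1ccc(C(=O)N(CCC(=O)NCc2ccccc2)Cc2ccc(C(=O)NO)cc2)cc1`, has not yet been measured in this assay. It differs from compound 2 in one place: methyl in place of methoxy on an aromatic carbon. Cut one bond further out, the change reads (4-methoxyphenyl)carbonyl to (4-methylphenyl)carbonyl. Going by the values given here, with no measured step of this kind to lean on, the expected step is small, a 1.1-fold higher number from compound 2 to compound 3 (0.04 log units; within the scatter), and may not reach beyond the scatter in either direction. Compound 3 is therefore estimated at 28 nM, within a range from 12 nM to 70 nM.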

Compound 3, half-maximal inhibitory concentration: 16.7 nM
Compound 3: the middle estimate sits 1.7-fold (0.22 log units) above what was measured, within the range that was stated.
By their numbers in this assay, from the lowest: compounds 3, 2 and 1 (each within the scatter of the next).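

For the compounds shown here, compound 2 and compound 3 form the first measured pair that differs in one place, and this assay gives a 1.5-fold lower number from compound 2 to compound 3 (0.18 log units; within the scatter) for that pair. On this aromatic carbon, para to a large group, methyl can therefore stand in place of methoxy, with its oxygen and one hydrogen-bond acceptor gone, and the two compounds cannot be told apart on this read-out. Nothing at hand accounts for the size of this step or assigns any role to either group.

Going by these compounds, whether an amine, a carboxylic acid or a longer alkyl chain at this carbon would move the number beyond the scatter remains open. So does the outcome of leaving this carbon with only hydrogen, or of placing chlorine there.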